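This account rests on a few compounds, and the source may have more. Where it says the series, first, only, none or still open, it means among the compounds named here.

Measured compounds:
compound 2, `CC(=O)c1ccc(CNc2ccc(-c3c(N)nc(N)nc3COCc3ccccc3)cc2)cc1`, in a functional assay on CHOK cells for antagonist activity at growth hormone secretagogue receptor type 1 (Homo sapiens), read by calcium flux (a lower number here means a stronger inhibitor, a higher number a weaker inhibitor), compound 2 gives 10 nM;
compound 1, `Nc1nc(N)c(-c2ccc(NCc3cc(F)c(S(=O)(=O)C(F)(F)F)c(F)c3)cc2)c(COCc2ccccc2)n1`, in this assay compound 1 gives 85 nM.

Of the two numbers, compound 2 holds the lowest; its nearest neighbour is compound 1, whose number is higher by a margin beyond the scatter. Within the data shown here, the two compounds share the same core and differ only in the group carried on the saturated chain carbon bound to the amine nitrogen on the aromatic ring, so the comparison shows only that the acetyl-bearing ring of compound 2 goes with the lower number of the two.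

Compound 3, `Nc1nc(N)c(-c2ccc(NCc3ccncc3)cc2)c(COCc2ccccc2)n1`, keeps that core and the same point of attachment. The change from compound 2 is pyridin-4-yl in place of 4-acetylphenyl on a saturated chain carbon bound to a nitrogen on an aromatic ring. Among the measured compounds shown here, no measured pair here makes this change, so its size in this assay can only be guessed from the spread between compound 2 and compound 1. The expectation is a modest rise in the number, that is a somewhat weaker inhibitor than compound 2, with the step from compound 2 to compound 3 estimated as a 4.0-fold higher number from compound 2 to compound 3 (0.60 log units; beyond the scatter). For compound 3 the estimate in this assay is 40 nM, within a range from 10 nM to 160 nM.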

Compound 3, half-maximal inhibitory concentration: 86 nM
For compound 3 the middle estimate is 2.2-fold (0.33 log units) below the measured one, and the stated range covers the measured number.
By their numbers in this assay, from the lowest: compound 2; then compounds 1 and 3 (each within the scatter of the next).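

Replacing 4-acetylphenyl with pyridin-4-yl on a saturated chain carbon bound to a nitrogen on an aromatic ring gives an 8.6-fold higher number from compound 2 to compound 3 (0.93 log units; beyond the scatter) in this assay, so this position responds to a change of ring in a single measured step. The earlier pair had shown only that compound 2 lay apart from compound 1, and compound 3 now stands within the scatter of compound 1 even though the two carry different groups here, which leaves compound 2 alone at the lower number among these three. Nothing shown accounts for the size of this step or says what sets compound 2 apart.

Compound 3 loses the acetyl group and swaps the ring of carbon only for one holding a nitrogen in the same step, so a plain phenyl group or a pyridin-4-yl ring carrying an acetyl group would be needed to tell these two changes apart. As far as these compounds go, how an amide, a carboxylic acid or a longer chain would read at this place also remains open.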